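From (1H-benzimidazol-2-yl)methyl to propyl on the sulfur

The source may report more compounds than this note shows. Statements on the series, on what has been measured and on what is new or still open speak of the compounds shown alone.

For the measured compounds named here, compound 3 `Cc1cc(Nc2cc(-c3ccccc3)[nH]n2)n2nc(SCc3nc4ccccc4[nH]3)nc2n1` gives 1790 nM in a functional assay on MGC-803 cells (Homo sapiens) for inhibition, read by MTT assay, with a stated time of 72 h (a higher number here means a weaker inhibitor, a lower number a stronger inhibitor), the lowest of the three numbers measured so far. Compound 1 `Cc1cc(Nc2cc(-c3ccccc3)[nH]n2)n2nc(SCCCc3ccccc3)nc2n1` gives 6510 nM and compound 2 `Cc1cc(Nc2cc(-c3ccccc3)[nH]n2)n2nc(SCc3cccc(Br)c3)nc2n1` gives 4820 nM; the steps into compound 3 are a 3.6-fold lower number from compound 1 to compound 3 (0.56 log units; beyond the scatter) and a 2.7-fold lower number from compound 2 to compound 3 (0.43 log units; beyond the scatter), both beyond the scatter, whereas a 1.4-fold lower number from compound 1 to compound 2 (0.13 log units; within the scatter) stays within it. Compound 4 `CCCSc1nc2nc(C)cc(Nc3cc(-c4ccccc4)[nH]n3)n2n1` differs from compound 3 by ethyl in place of 1H-benzimidazol-2-yl on a saturated chain carbon bound to a sulfur, so the sulfanyl substituent changes from (1H-benzimidazol-2-yl)methyl to propyl. Both measured steps into compound 3 pair the 1H-benzimidazol-2-yl group with the lower number; its removal should undo that gain. For compound 4 the expected step is a 3.9-fold higher number from compound 3 to compound 4 (0.59 log units; beyond the scatter), towards a weaker inhibitor. Compound 4 is estimated at 7000 nM, within 3000 nM to 16000 nM.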

Compound 4, half-maximal inhibitory concentration: 12600 nM
The estimate for compound 4 lay 1.8-fold (0.26 log units) below the measured number, and the stated range covers the measured number.
By their numbers in this assay, from the lowest: compound 3; then compounds 2, 1 and 4 (each within the scatter of the next, the first and the last beyond it).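

In this assay propyl gives up the gain tied to 1H-benzimidazol-2-yl, with a 7.0-fold higher number from compound 3 to compound 4 (0.85 log units; beyond the scatter) as the largest step in the series, and a 2.6-fold higher number from compound 2 to compound 4 (0.42 log units; beyond the scatter) shows that 3-bromophenyl also separates from propyl beyond the scatter. Removing the phenyl from the chain end gives a 1.9-fold higher number from compound 1 to compound 4 (0.29 log units; within the scatter) and stays within the scatter, so compound 1 goes against any rule that a ring on this chain lowers the number. No measurement at hand explains these steps. Open, going by these compounds, is whether a chain ending in an amine or a carboxylic acid would reach the level of compound 3.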